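Fluoro scan on the pendant phenyl of the sulfonamide series

The compounds below may be only part of what the source reports. "The series", "measured", "known", "first", "only" and "open" are said of these compounds alone.

Compound 2 `NS(=O)(=O)c1ccc(-n2ncc3c(=O)[nH]c(-c4ccccc4)nc32)cc1` has been measured in a functional assay on HepG2 cells (Homo sapiens) for cytotoxicity, read by MTT assay, with a stated time of 72 h (a higher number here means a weaker inhibitor, a lower number a stronger inhibitor), where compound 2 gives 77600 nM. Going by the values given here, this is the only number in the set. Compound 1 `N#Cc1cnn(-c2ccc(S(N)(=O)=O)cc2)c1N` reaches only the limit of the assay: in this assay compound 1 gives > 100000 nM, which is a limit and not a number. Among the compounds with values here, the position of compound 2 is therefore fixed only against that limit (the limit of > 100000 nM in this assay, at which 1 of the 2 values shown sits), and no step between two measured numbers exists to calibrate the series.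

Compound 3 `NS(=O)(=O)c1ccc(-n2ncc3c(=O)[nH]c(-c4ccc(F)cc4)nc32)cc1` is the next compound. It differs from compound 2 by fluoro in place of hydrogen on an aromatic carbon, or phenyl to 4-fluorophenyl when the difference is cut one bond further out. Within the data shown here, no comparable step has been measured here. A single fluorine on the pendant ring is expected to leave the read-out within the usual scatter, with no direction beyond it, so the step from compound 2 to compound 3 is estimated as a 1.1-fold lower number from compound 2 to compound 3 (0.04 log units; within the scatter). Compound 3 is expected to give 70000 nM in this assay, with an estimated range from 30000 nM to 150000 nM, and a fair chance that only a limit is reported.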

Compound 3, half-maximal inhibitory concentration: 2660 nM
For compound 3 the middle estimate is 26-fold (1.42 log units) above the measured one, and the stated range ends above it.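

In this assay the pendant phenyl is not a silent position: fluoro in place of hydrogen on this aromatic carbon, para to a large group, gives a 29-fold lower number from compound 2 to compound 3 (1.46 log units; beyond the scatter) and so a large change from the addition of one heavy atom. Going by these compounds alone, this is the first step between two measured numbers, and it shows that the read-out can respond strongly to a small change on this ring, which the earlier compounds could not show. Within the data shown here, the set still holds one value that is a limit and not a number, the one for compound 1: the limit of > 100000 nM in this assay, at which 1 of the 3 values shown sits.

From the compounds shown here alone, whether this step belongs to fluoro itself or would follow from any group at this carbon stays open, and chloro, methoxy or an amine in the same place would separate those two readings. A single pair also gives no cause for the step and does not show whether it would carry over to the other carbons of the pendant ring.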